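Chloro on the acetamido chain carbon: cytotoxicity on MT4 cells

The compounds below may be only part of what the source reports. "The series", "measured", "known", "first", "only" and "open" are said of these compounds alone.

Compound 1 `CCC(=O)Nc1ccc(-c2nc3cc(C(F)(F)F)ccc3[nH]2)cc1`: >= 100000 nM
Compound 2 `CC(=O)Nc1ccc(-c2nc3cc(C(F)(F)F)ccc3[nH]2)cc1`: 19000 nM

Two compounds sharing one core carry different amide groups on the aryl nitrogen. In an ADME assay on MT4 cells (Homo sapiens) for cytotoxicity, read by MTT assay, with a stated time of 96 h (a lower number here means that less compound is tolerated, a higher number that more compound is tolerated), compound 1 gives >= 100000 nM, which is a limit of the assay rather than a number (the limit of >= 100000 nM in this assay, at which 1 of the 2 values shown sits). In this assay, for the measured compounds named here, compound 2 gives 19000 nM, the only numerical value shown. Going by the values given here, the step of an at least 5.2-fold lower number from compound 1 to compound 2 (0.72 log units; beyond the scatter) is the single measured step, and it sits on the same saturated chain carbon bound to the carbonyl carbon that is altered next.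

Compound 3 `O=C(CCl)Nc1ccc(-c2nc3cc(C(F)(F)F)ccc3[nH]2)cc1` differs from compound 2 by chloro in place of hydrogen on a saturated chain carbon bound to a carbonyl carbon. Among the compounds with values here, the one measured step shows that this chain carbon is sensitive to substitution, but it ran from methyl to hydrogen, not from hydrogen to chloro, so its direction does not transfer directly. He therefore expects a step of modest size, with the lower number somewhat more likely, estimated as a 1.9-fold lower number from compound 2 to compound 3 (0.28 log units; within the scatter). For compound 3 in this assay he estimates 10000 nM, within a range from 3000 nM to 40000 nM.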

Compound 3, half-maximal cytotoxic concentration: 5000 nM
Estimate against measurement, compound 3: 2.0-fold (0.30 log units) above; low and high end bracket the measured number.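

In this assay, the step of a 3.8-fold lower number from compound 2 to compound 3 (0.58 log units; beyond the scatter) shows that chloro in place of hydrogen on this saturated chain carbon bound to a carbonyl carbon has an effect beyond the scatter, something the earlier pair, which differed only by methyl and hydrogen, could not show. Together with the earlier step, it places the three compounds in one order, with the number falling from methyl through hydrogen to chloro, and none of the three goes against that order; the whole span is the step of an at least 20-fold lower number from compound 1 to compound 3 (1.30 log units; beyond the scatter), the largest shown at this carbon. For compound 1, the value >= 100000 nM is a limit and not a number: the limit of >= 100000 nM in this assay, at which 1 of the 3 values shown sits.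

The three compounds leave open whether the order reflects something general about this carbon or is specific to the chloro and methyl groups, and fluoro, bromo, a hydroxyl or an amine on the same carbon would bear on that question. They also leave open whether chloro keeps this effect on a longer chain or when the amide hydrogen is replaced by a methyl group.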